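Swapping a biphenyl for a naphthalene on the sulfonamide

The source may hold more compounds than are shown below. What is called first, only, known or untested is meant among the compounds shown, and "the series" means these compounds.

Compound 1 `Cc1ccc(NS(=O)(=O)c2ccc(Cl)cc2)cc1Nc1nccc(-c2cccnc2)n1`: 7790 nM
Compound 2 `COc1cc(-c2ccnc(Nc3cc(NS(=O)(=O)c4ccc(-c5ccccc5)cc4)ccc3C)n2)cc(OC)c1OC`: 6930 nM

In a functional assay on MDA-MB-231 cells (Homo sapiens) for cytotoxicity, read by MTT assay, with a stated time of 24 h (on this read-out lower numbers stand for stronger inhibition and higher numbers for weaker inhibition), compound 2 gives 6930 nM, and compound 1 gives 7790 nM, a gap within the usual scatter, so neither stands apart from the other. Compound 3 `COc1cc(-c2ccnc(Nc3cc(NS(=O)(=O)c4ccc5ccccc5c4)ccc3C)n2)cc(OC)c1OC` has not been measured. It differs from compound 2 in one place: naphthalen-2-yl in place of 4-phenylphenyl on a sulfonyl sulfur. Going by the values given here, with no measured pair showing such a swap, the expectation rests on the similar size of the two groups: a step from compound 2 to compound 3 of about a 1.0-fold higher number from compound 2 to compound 3 (0.00 log units; within the scatter), not beyond the scatter in either direction, is expected. Compound 3 is therefore estimated at 7000 nM, within the range 3000 nM to 16000 nM.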

Compound 3, half-maximal inhibitory concentration: 7550 nM
Estimate against measurement, compound 3: 1.1-fold (0.03 log units) below, and the stated range covers the measured number.
By their numbers in this assay, from the lowest: compounds 2, 3 and 1 (each within the scatter of the next).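

In this assay, putting naphthalen-2-yl in place of 4-phenylphenyl on a sulfonyl sulfur gives a 1.1-fold higher number from compound 2 to compound 3 (0.04 log units; within the scatter), so compound 2 and compound 3 cannot be told apart. This is the first single-place change shown at this position, and here two carbon-only groups, each with two aromatic rings, give matching results. Nothing measured on hand offers an explanation for this match.

On these data alone, it remains open whether a different group on the sulfonyl sulfur, such as a methyl, a pyridine ring or a phenyl bearing a carboxylic acid, would move the number beyond the scatter.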